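Dropping the pyridine from an inactive thiazole sulfoxide

The source may hold more compounds than are shown below. What is called first, only, known or untested is meant among the compounds shown, and "the series" means these compounds.

Of the compounds shown here, two have so far been tested in a functional assay on HepG2 cells (Homo sapiens) for cytotoxicity, read by MTT assay, with a stated time of 48 h; a lower number here means a stronger inhibitor, a higher number a weaker inhibitor. Compound 1 `CC(c1nccs1)C(C#N)(C#N)CCC(F)=C(F)F` gives only a limit there, > 120000 nM. Compound 2 `[O-][S+](CCC(F)=C(F)F)c1ncc(-c2ccncc2)s1` likewise gives only a limit, > 120000 nM. So both measured values sit at the same limit of the method, as the evidence shows (the limit of > 120000 nM in this assay, at which 2 of the 2 values shown sit), and compound 2 stands nowhere above or below compound 1: the two are simply indistinguishable in this assay, and no step between measured compounds can be drawn from them.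

Compound 3 `[O-][S+](CCC(F)=C(F)F)c1nccs1` is the next compound. It differs from compound 2 in one place (hydrogen in place of pyridin-4-yl on an aromatic carbon). Among the compounds with values here, no measured step covers this change, so its effect must be judged from the two readings at hand. Both compound 1 and compound 2 give only limits in this assay, and nothing among them points to a gain in potency from losing the pyridin-4-yl group. The step from compound 2 to compound 3 is therefore expected to be none beyond the usual scatter, a step that the limit leaves unreadable from compound 2 to compound 3, most likely with compound 3 again reported only as a limit. Compound 3 is estimated at 150000 nM, with a range from 60000 nM to 400000 nM.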

Compound 3, half-maximal inhibitory concentration: > 120000 nM
Compound 3: a limit, no number; the forecaster's own chance of this, stated with the estimate: 85%; the middle value lies beyond the limit too.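

Compound 2 and compound 3 both give only a limit in this assay, so the effect of putting hydrogen in place of pyridin-4-yl cannot be read: the limit of > 120000 nM in this assay, at which 3 of the 3 values shown sit.

The compounds shown leave open which structure, if any, would give an actual number rather than a limit in this assay.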